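This account rests on a few compounds, and the source may have more. Where it says the series, first, only, none or still open, it means among the compounds named here.

Measured in an assay for inhibition of MAP kinase-interacting serine/threonine-protein kinase 1 (Homo sapiens), read by luminescence and ADP-Glo, with a stated time of 2 h; a lower number here means a stronger inhibitor, a higher number a weaker inhibitor:
compound 1, `O=c1ccc(-c2n[nH]c3ncc(Br)cc23)cn1Cc1ccccc1`, gives 56 nM.
compound 2, `O=c1ccc(-c2ccc3cn[nH]c3c2)cn1Cc1ccccc1`, gives 315 nM.
compound 3, `NC(=O)c1ccc(Cn2cc(-c3ccc4cn[nH]c4c3)ccc2=O)cc1`, gives only a limit, > 2000 nM.

Compound 3 therefore stands at the edge of what this assay reports: its entry is the limit of > 2000 nM in this assay, at which 1 of the 3 values shown sits, a boundary rather than a number, so only the direction past it is known. Among the compounds with values here, the one measured step that reaches compound 3 is an at least 6.3-fold higher number from compound 2 to compound 3 (0.80 log units; beyond the scatter), which means adding the carbamoyl cost potency by a clear margin. Compound 4, `O=c1ccc(-c2ccc3cn[nH]c3c2)cn1Cc1ccc(C(F)(F)F)cc1`, is the next compound; its difference from compound 3 is trifluoromethyl in place of carbamoyl on an aromatic carbon. The carbamoyl that accompanied the loss in an at least 6.3-fold higher number from compound 2 to compound 3 (0.80 log units; beyond the scatter) is thus removed, and the number is expected to fall back toward the value compound 2 shows. The trifluoromethyl, however, has no measured counterpart among these compounds, so the expectation stays broad and a repeat of the limit cannot be ruled out. Compound 4 is estimated at 500 nM, within 150 nM to 3000 nM. This expected change amounts to an at least 4.0-fold lower number from compound 3 to compound 4 (0.60 log units; beyond the scatter).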

Compound 4, half-maximal inhibitory concentration: 1170 nM
Estimate against measurement, compound 4: 2.3-fold (0.37 log units) below, and the stated range covers the measured number.
By their numbers in this assay, from the lowest: compound 1; then compound 2; then compound 4. At a limit, above all of these: compound 3.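

Putting a group at this position, on the six-membered aromatic ring of carbon only and para to a large group, costs potency even when that group is not carbamoyl: trifluoromethyl in place of hydrogen gives a 3.7-fold higher number from compound 2 to compound 4 (0.57 log units; beyond the scatter). The comparison between the two groups themselves is much less firm, with an at least 1.7-fold lower number from compound 3 to compound 4 (0.23 log units; that floor lies within the scatter). Compound 3 is held at a limit and not a number, so the true distance between the two groups stays unknown: the limit of > 2000 nM in this assay, at which 1 of the 4 values shown sits.

Still open, from the compounds shown here alone, is how other groups at this position would compare with the hydrogen of compound 2, for example a fluorine, a methyl, an amine or a carboxylic acid. Also open, going by these compounds, is whether trifluoromethyl would have a similar effect on the core of compound 1.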